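The compounds below may be only part of what the source reports. "The series", "measured", "known", "first", "only" and "open" are said of these compounds alone.

Measured so far:
compound 1, `Brc1ccc2ccn(CCN3CCN4CCCC4C3)c2c1`: 72%
compound 2, `Brc1ccc2ccn(CCN3CCN(C4CCCCC4)CC3)c2c1`: 36%
compound 3, `CN1CCCN(CCn2ccc3ccc(OCc4ccccc4)cc32)CC1`: 28%

These three compounds were tested in an assay on HEK293 cells for binding affinity to 5-hydroxytryptamine receptor 7 (Homo sapiens), read by radioligand binding, tested at 1 uM; a lower number here means less inhibition, a higher number more inhibition at the concentration tested (going by the name of the read-out). Compound 3 has the lowest of the three numbers. Its nearest neighbour is compound 2, whose value lies within the scatter of the method, so no order between those two can be read. Compound 1 stands much further off, beyond the scatter, so compound 1 inhibits more than compound 3 at this concentration.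

The next compound, compound 4, `CN1CCCN(CCn2ccc3ccc(-c4ccsc4)cc32)CC1`, has not yet been measured. It differs from compound 3 in one place: thiophen-3-yl in place of benzyloxy on an aromatic carbon. Within the data shown here, no pair of measured compounds shows this same change, so its effect can only be guessed from the spread seen among compounds 1 to 3.

The expectation for compound 4 is a modest rise, a step of a number 10 percentage points higher from compound 3 to compound 4 (within the scatter), roughly at the edge of the scatter. Compound 4 is therefore estimated at 38%, with a likely range from 15% to 65%.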

Compound 4, a percentage reported as inhibition, at one concentration (the size of the read-out at that concentration, not a potency): 68%
Compound 4: the middle estimate sits 30 percentage points below what was measured, outside the stated range (above it).
By their numbers in this assay, from the lowest: compounds 3 and 2 (each within the scatter of the next); then compounds 4 and 1 (each within the scatter of the next).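

Replacing benzyloxy with thiophen-3-yl on this aromatic carbon gives, in this assay, a number 40 percentage points higher from compound 3 to compound 4 (beyond the scatter). Among these compounds, with the rest of the molecule held the same, this shows that the group at this position can by itself strongly change the inhibition seen at the concentration tested, something the earlier compounds, which differ in more than one place, could not show. Nothing measured here explains why this change has such an effect.

This one change removes the oxygen link, replaces a six-membered carbon ring with a five-membered sulfur-containing ring and lowers the heavy-atom count all at once, so the pair cannot show which of these matters. As far as these compounds go, how a directly attached phenyl, a thiophen-2-yl or an amine would behave at this position remains open.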